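The compounds below may be only part of what the source reports. "The series", "measured", "known", "first", "only" and "open" are said of these compounds alone.

In a toxicity assay on HeLa cells (Homo sapiens) for cytotoxicity, read by MTT assay, with a stated time of 24 h (on this read-out higher numbers stand for weaker inhibition and lower numbers for stronger inhibition), two compounds of this series have been read so far. Compound 1 `Cc1ncc([N+](=O)[O-])n1CC(O)CSC(=S)N1CCN(c2ccccc2)CC1` gives > 5000000 nM, which is a limit of the assay and not a number. Among the measured compounds shown here, compound 2 `Cc1ncc([N+](=O)[O-])n1CC(O)CSC(=S)N1CCN(c2ccccn2)CC1` gives 2970000 nM, the only true number available. Its standing can be judged only against the reading for compound 1.

Compound 3 `Cc1ncc([N+](=O)[O-])n1CC(O)CSC(=S)N1CCN(c2ccccc2F)CC1` follows from compound 2 by 2-fluorophenyl in place of pyridin-2-yl on an amine nitrogen in a ring. For the measured compounds named here, one measured step bears on this change, an at least 1.6-fold lower number from compound 1 to compound 2 (0.22 log units; that floor lies within the scatter), in which pyridin-2-yl took the place of phenyl at that same nitrogen. Compound 3 again carries an aromatic ring of carbon only, so that step is read in reverse, as a weak hint towards a higher number. Going by the values given here, no measured step involves fluorine. A shift no larger than the scatter is therefore expected, and the expected step is a 1.3-fold higher number from compound 2 to compound 3 (0.13 log units; within the scatter). The value for compound 3 is estimated at 4000000 nM, within an expected range from 1800000 nM to 9000000 nM.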

Compound 3, half-maximal inhibitory concentration: 3240000 nM
The estimate for compound 3 lay 1.2-fold (0.09 log units) above the measured number; measured number inside the range.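

In this assay, the result at this amine nitrogen in a ring is a 1.1-fold higher number from compound 2 to compound 3 (0.04 log units; within the scatter). So 2-fluorophenyl and pyridin-2-yl cannot be told apart here, even though one brings fluorine and a ring of carbon only, while the other has a ring hetero atom counted as a hydrogen-bond acceptor. Fluoro in place of hydrogen on an aromatic carbon, a change that no earlier pair could address, gives an at least 1.5-fold lower number from compound 1 to compound 3 (0.18 log units; that floor lies within the scatter), and this step can be read only as a floor, so its true size remains unknown: the limit of > 5000000 nM in this assay, at which 1 of the 3 values shown sits.

From the compounds shown here alone, what stays open is whether any group at this nitrogen can move the number beyond the scatter, for instance a benzyl group, a longer chain or a phenyl ring carrying a carboxylic acid. Also open is whether a change away from this nitrogen, such as an amine in place of the nitro group on the shared core, would matter more than the exchanges among these three aromatic groups.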